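Ester aryl swap on a nitrophenyl amide cyclohexanol core

The compounds below may be only part of what the source reports. "The series", "measured", "known", "first", "only" and "open" are said of these compounds alone.

Three cyclohexane esters bearing the same nitrophenyl amide have been measured in a functional assay on MCF7 cells (Homo sapiens) for inhibition, read by MTT assay, with a stated time of 72 h; on this read-out lower numbers stand for stronger inhibition and higher numbers for weaker inhibition. Compound 1 `Cc1ccc(C(=O)OC2(C(=O)Nc3ccc([N+](=O)[O-])cc3)CCCCC2)cc1` gives 9.8 nM, compound 2 `O=C(OC1(C(=O)Nc2ccc([N+](=O)[O-])cc2)CCCCC1)c1ccc([N+](=O)[O-])cc1` gives 8.7 nM, and compound 3 `O=COC1(C(=O)Nc2ccc([N+](=O)[O-])cc2)CCCCC1` gives 35.4 nM. Compound 2 thus carries the lowest of the three numbers, with compound 1 within the scatter of it and compound 3 the furthest away. Compound 4 `CC(=O)Oc1ccccc1C(=O)OC1(C(=O)Nc2ccc([N+](=O)[O-])cc2)CCCCC1` is not yet measured; it differs from compound 2 by 2-acetoxyphenyl in place of 4-nitrophenyl on a carbonyl carbon. Among the compounds with values here, two measured steps bear on this change. The step of a 1.1-fold lower number from compound 1 to compound 2 (0.05 log units; within the scatter) shows that exchanging the group on the aromatic ring of the ester hardly moves the number, while the step of a 4.1-fold higher number from compound 2 to compound 3 (0.61 log units; beyond the scatter) shows that removing the aryl ester altogether costs a modest amount. Since compound 4 keeps an aryl ester and only alters its substituent, the expected step of a 1.5-fold higher number from compound 2 to compound 4 (0.17 log units; within the scatter) in this assay is small, if anything slightly upward. Compound 4 is therefore estimated at 13 nM, within a range of 6 nM to 30 nM.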

Compound 4, half-maximal inhibitory concentration: 16.9 nM
For compound 4 the middle estimate is 1.3-fold (0.11 log units) below the measured one, and the stated range covers the measured number.
By their numbers in this assay, from the lowest: compounds 2, 1 and 4 (each within the scatter of the next); then compound 3.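

In this assay, the carbonyl carbon accepts a 2-acetoxyphenyl group as readily as the earlier aryl groups: a 1.9-fold higher number from compound 2 to compound 4 (0.29 log units; within the scatter) and a 1.7-fold higher number from compound 1 to compound 4 (0.24 log units; within the scatter) both stay within the scatter, so three different aryl groups now give numbers that cannot be told apart. The gain over hydrogen, seen before only with 4-methylphenyl and 4-nitrophenyl, also holds for this third aryl group, with a 2.1-fold lower number from compound 3 to compound 4 (0.32 log units; beyond the scatter) lying beyond the scatter, though modest. Nothing at hand explains why these aryl groups behave alike.

Going by these compounds, it remains open whether a longer alkyl chain on the carbonyl carbon would match the aryl groups, or whether a carboxylic acid on the ring would. On these data alone, all four compounds also keep the 4-nitrophenyl amide, so the effect of an amine in place of its nitro group remains unknown.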